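Compound 4: 4-ethyl-1,3-oxazol-2-yl in place of trifluoromethyl

The compounds below may be only part of what the source reports. "The series", "measured", "known", "first", "only" and "open" are said of these compounds alone.

In an in vitro ADME assay on microsomes from liver (Rattus norvegicus) for metabolic stability (on this read-out higher numbers stand for fast clearance and lower numbers for slow clearance), compound 1 `Cc1ccc(Cn2c(=O)[nH]c3c(N)nc(-c4ncco4)cc32)cn1` gives < 8.5 mL.min-1.g-1, which is a limit. Compound 2 `Cc1ccc(Cn2c(=O)[nH]c3c(N)nc(C(F)(F)F)cc32)cn1` gives < 8.5 mL.min-1.g-1, also a limit and not a number. Compound 3 `Cc1cc(Cn2c(=O)[nH]c3c(N)nc(C(F)(F)F)cc32)no1` gives < 9 mL.min-1.g-1, again a limit. Compound 2 therefore has no exact position, and neither of the other two values offers a number to compare it with.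

Compound 4 `CCc1coc(-c2cc3c([nH]c(=O)n3Cc3ccc(C)nc3)c(N)n2)n1` departs from compound 2 as follows: 4-ethyl-1,3-oxazol-2-yl in place of trifluoromethyl on an aromatic carbon. The new group sits on the same aromatic carbon, next to the ring nitrogen.

The nearest measured change is a step that the two limits leave unreadable from compound 1 to compound 2, which involves the same place and a 1,3-oxazol-2-yl group without the ethyl. The other is a step that the two limits leave unreadable from compound 2 to compound 3, which concerns a different place and bears on this question only weakly. Among the measured compounds shown here, neither gives a size, and no measured compound carries the ethyl group.

The expectation therefore leans on compound 1, whose limit is < 8.5 mL.min-1.g-1, as the closest neighbour. The expected change in this assay is an at least 1.1-fold higher number from compound 2 to compound 4 (0.07 log units; that floor lies within the scatter), small and towards faster clearance. Compound 4 is estimated at 10 mL.min-1.g-1, with an expected range from 6 mL.min-1.g-1 to 20 mL.min-1.g-1.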

Compound 4, intrinsic clearance in microsomes: < 8.5 mL.min-1.g-1
Compound 4: only a limit was reported; the forecaster's own chance of this, stated with the estimate: 50%; at least 1.1-fold (0.07 log units) between middle value and limit.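

In this assay compound 4 gives < 8.5 mL.min-1.g-1, which is a limit and not a number. Its steps from compound 1 and from compound 2 therefore cannot be read: the limit of < 8.5 mL.min-1.g-1 in this assay, at which 3 of the 4 values shown sit.

The compounds shown leave open how large the clearance of each one is, and whether 4-ethyl-1,3-oxazol-2-yl, trifluoromethyl or the added ethyl changes it at all.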